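Shortening the Amide Substituent of Compound 3

This account rests on a few compounds, and the source may have more. Where it says the series, first, only, none or still open, it means among the compounds named here.

Compound 1 `CC[C@@H]1C(=O)N(C)c2cnc(-n3ccc4cc(F)ccc43)nc2N1C1CCCC1` gives "not active" (no number reported) in a functional assay on HeLa cells (Homo sapiens) for antiproliferative activity, read by CCK-8 assay, with a stated time of 72 h; a higher number here means a weaker inhibitor of growth, a lower number a stronger inhibitor of growth.
Compound 2 `CC[C@@H]1C(=O)N(C)c2cnc(-n3ccc4cc(C(=O)NC5CCCC5)ccc43)nc2N1C1CCCC1` gives 247 nM.
Compound 3 `CCCCNC(=O)c1ccc2c(ccn2-c2ncc3c(n2)N(C2CCCC2)[C@H](CC)C(=O)N3C)c1` gives 346 nM.

Compound 1, which lacks the amide altogether, was not active, so no number stands for it. Among the two numbers, compound 3 has the higher one, and its nearest neighbour is compound 2; the step of a 1.4-fold higher number from compound 2 to compound 3 (0.15 log units; within the scatter) lies within the scatter, so the two cannot be ordered. Compound 4 `CC[C@@H]1C(=O)N(C)c2cnc(-n3ccc4cc(C(=O)NC)ccc43)nc2N1C1CCCC1` differs from compound 3 by hydrogen in place of propyl on a saturated chain carbon bound to an amide-type nitrogen. Among the measured compounds shown here, the only measured step that bears on this change, a 1.4-fold higher number from compound 2 to compound 3 (0.15 log units; within the scatter), also reduced the group on the amide nitrogen and stayed within the scatter. Taking that as the guide, a step of a 1.4-fold higher number from compound 3 to compound 4 (0.16 log units; within the scatter) is expected, leaving compound 4 at an estimated 500 nM with a range from 200 nM to 1500 nM.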

Compound 4, concentration for 50% growth inhibition: 768 nM
The estimate for compound 4 lay 1.5-fold (0.19 log units) below the measured number, and the stated range covers the measured number.
By their numbers in this assay, from the lowest: compounds 2 and 3 (each within the scatter of the next); then compound 4.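

Shortening the amide substituent from butyl to methyl gives the first step at this position that lies beyond the scatter in this assay (a 2.2-fold higher number from compound 3 to compound 4 (0.35 log units; beyond the scatter)). The cyclopentyl amide shows a similar gap (a 3.1-fold higher number from compound 2 to compound 4 (0.49 log units; beyond the scatter)), so methyl separates from both larger groups, although butyl and cyclopentyl themselves cannot be ordered. Nothing available explains this difference. The compounds shown leave open where between methyl and butyl the change sets in, as an ethyl or propyl chain would show. They also leave open whether a longer chain, or an amine at the end of the chain, would give a lower number.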